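Adding 4-fluorophenoxy to a compound already at a limit

The compounds below may be only part of what the source reports. "The series", "measured", "known", "first", "only" and "open" are said of these compounds alone.

In a physicochemical assay for solubility, using the shake flask method, in simulated intestinal fluid, measured as kinetic solubility, with a stated time of 2 h, at 25 degrees C, at pH 6.5 (on this read-out lower numbers stand for lower solubility and higher numbers for higher solubility), compound 1 (`COC(=O)c1nc(C)c2c(c1N)C(=O)N(Cc1ccccc1)C2=O`) gives 7400 nM. In this assay, compound 2 (`Cc1noc(-c2nc(C)c3c(c2N)C(=O)N(Cc2ccccc2)C3=O)n1`) gives < 5000 nM, which is a limit of the assay and not a number. All that is known of compound 2 is therefore a ceiling, with no exact position. The next structure, compound 3 (`Cc1noc(-c2nc(C)c3c(c2N)C(=O)N(Cc2ccc(Oc4ccc(F)cc4)cc2)C3=O)n1`), has 4-fluorophenoxy in place of hydrogen on an aromatic carbon of a six-membered aromatic ring of carbon only, para to a large group (4-fluorophenoxy in place of hydrogen on an aromatic carbon).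

For the measured compounds named here, the only measured step is an at least 1.4-fold lower number from compound 1 to compound 2 (0.17 log units; that floor lies within the scatter). It swaps 3-methyl-1,2,4-oxadiazol-5-yl for methoxycarbonyl at a different place, so it bears only loosely on this change and gives no measured size for it. Going by the values given here, with no measured example of adding this group, the forecast is a judgement: a moderately lower number is expected in this assay, and another limit is the likeliest report. The expected step is a step that the limit leaves unreadable from compound 2 to compound 3. For compound 3 the estimated value is 2000 nM, with an expected range from 400 nM to 5000 nM.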

Compound 3, solubility: 23800 nM
The estimate for compound 3 lay 12-fold (1.08 log units) below the measured number; measured number outside the range, above it.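

In this assay, 4-fluorophenoxy on an aromatic carbon of a six-membered aromatic ring of carbon only, para to a large group, gives an at least 4.7-fold higher number from compound 2 to compound 3 (0.67 log units; beyond the scatter). For the compounds shown here, this is the first look at this position, since the earlier step changed a different place, and here a large addition of 8 heavy atoms, including one more aromatic ring, goes with a higher number rather than a lower one. The step has only a floor and its full size stays unknown, because compound 2 stands at a limit of the assay: the limit of < 5000 nM in this assay, at which 1 of the 3 values shown sits.

On these data alone, what a plain phenoxy, a methoxy or an amine would give at this same position remains open, so the shares of the fluorine, the oxygen and the added ring in this step cannot be told apart. Also open, as far as these compounds go, is whether 4-fluorophenoxy would go with a similar step when methoxycarbonyl stands in place of 3-methyl-1,2,4-oxadiazol-5-yl, as one pair of compounds cannot show whether this holds beyond that pair.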